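This account rests on a few compounds, and the source may have more. Where it says the series, first, only, none or still open, it means among the compounds named here.

Measured so far:

Compound 1 `Cc1ccc(C)c(NC(=O)c2ccc(/N=N\c3c[nH]c4ccccc34)cc2)c1`; in a functional assay on P388 cells (Mus musculus) for inhibition, read by MTT assay, with a stated time of 72 h (a higher number here means a weaker inhibitor, a lower number a stronger inhibitor), compound 1 gives "not active" (no number reported).
Compound 2 `O=C(Nc1cccc(Cl)c1)c1ccc(/N=N\c2c[nH]c3ccccc23)cc1`; in this assay compound 2 gives 267000 nM.
Compound 3 `Cc1ccccc1NC(=O)c1ccc(/N=N\c2c[nH]c3ccccc23)cc1`; in this assay compound 3 gives "not active" (no number reported).

All three compounds share the same core, and they differ only in the aromatic group attached to the amide nitrogen. Compound 3 carries a 2-methylphenyl there, and in this assay compound 3 gives "not active" (no number reported), so no number stands for it. Compound 1 is in the same position, with no number either. Compound 2, with a 3-chlorophenyl, is the only one of the three for which a number was recorded at all, and that number is very high.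

The next compound, compound 4 `O=C(Nc1cccc([N+](=O)[O-])c1)c1ccc(/N=N\c2c[nH]c3ccccc23)cc1`, has not been measured in this assay. Its change from compound 3 is 3-nitrophenyl in place of 2-methylphenyl on an amide-type nitrogen.

Going by the values given here, no pair of measured compounds that differ in one place has a numbered step, so there is no measured change to lean on. Among the compounds with values here, what can be said is that the one compound bearing a substituted phenyl with a group in the 3-position, compound 2, gave a number, while the two with a methyl-bearing phenyl gave none. On that basis the expectation for compound 4 is either no number again or a number in the same very high region as compound 2, and no large movement beyond the scatter in either direction is expected.

Compound 4 is therefore estimated at 250000 nM, with an expected range from 80000 nM to 800000 nM.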

Compound 4, half-maximal inhibitory concentration: 51900 nM
Compound 4: the middle estimate sits 4.8-fold (0.68 log units) above what was measured; measured number below the stated range.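

In this assay, going by these compounds alone, putting nitro in place of chloro on an aromatic carbon gives a 5.1-fold lower number from compound 2 to compound 4 (0.71 log units; beyond the scatter), the first measured change, and it shows that the group on the amide-type nitrogen can shift the number beyond the usual scatter. Compound 3, with 2-methylphenyl, gives "not active" (no number reported), whereas compound 4, with 3-nitrophenyl, gives 51900 nM, so this swap separates a compound without a recorded number from one with a number, although no size can be given for that change. Nothing measured here explains why the nitro compound has the lower number.

On these data alone, it remains open whether an amine or a carboxylic acid in place of the nitro group would lower the number further or raise it again, and how a plain phenyl with no added group would compare. The shared core is the same in all four compounds, so these results say nothing about what a change to the core would do.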